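Methoxy for thiophen-2-yl on the shared core

The source may hold more compounds than are shown below. What is called first, only, known or untested is meant among the compounds shown, and "the series" means these compounds.

Compound 1 `Nc1ncnc2[nH]cc(Sc3cccs3)c12` carries an amino group on the shared core; in a functional assay on HL-60 cells (Homo sapiens) for cytotoxicity, read by XTT assay, with a stated time of 6 days (a higher number here means a weaker inhibitor, a lower number a stronger inhibitor), compound 1 gives 13900 nM. Compound 2 `c1csc(Sc2c[nH]c3ncnc(-c4cccs4)c23)c1` carries thiophen-2-yl at that place, and in this assay compound 2 gives 21100 nM. Among the compounds with values here, the only step so far is a 1.5-fold higher number from compound 1 to compound 2 (0.18 log units; within the scatter); it lies within the scatter, so compound 1 and compound 2 are not separated by the numbers in hand, and compound 2 stands at a value the data cannot tell apart from that of compound 1.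

Compound 3 `COc1ncnc2[nH]cc(Sc3cccs3)c12` has not been measured. Relative to compound 2 it differs by methoxy in place of thiophen-2-yl on an aromatic carbon. Within the data shown here, the one step that bears on this position, a 1.5-fold higher number from compound 1 to compound 2 (0.18 log units; within the scatter), shows that exchanging amino for thiophen-2-yl there moved the number by less than the scatter. Nothing in hand suggests that methoxy at the same place should behave differently. The change is therefore expected to be small, a 1.2-fold lower number from compound 2 to compound 3 (0.09 log units; within the scatter), with no direction beyond the scatter. For compound 3 in this assay the expected value is 17000 nM, with a range from 7000 nM to 40000 nM.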

Compound 3, half-maximal inhibitory concentration: > 25000 nM
Compound 3: no number, only a limit; the forecaster's own chance of this, stated with the estimate: 15%; middle value at least 1.4-fold (0.16 log units) from the limit.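

Compound 3 gives > 25000 nM in this assay, which is a limit of the assay and not a number: the limit of > 25000 nM in this assay, at which 1 of the 3 values shown sits.

Read as floors, the new steps are an at least 1.1-fold higher number from compound 2 to compound 3 (0.07 log units; that floor lies within the scatter) and an at least 1.7-fold higher number from compound 1 to compound 3 (0.25 log units; that floor lies within the scatter); both floors lie within the scatter, so the true size of either gap cannot be read from them. What is new is a direction: the earlier pair gave no direction at this aromatic carbon, while the limit rules out a lower number with methoxy, even though methoxy is the smaller entering group, with 2 heavy atoms and no ring, in place of thiophen-2-yl with 5 heavy atoms.

Going by these compounds, it remains open whether any group at this place, such as a dimethylamino group, a carboxylic acid or a longer alkoxy chain, would give a number clearly separated from those of amino and thiophen-2-yl. On these data alone, the contribution of the sulfur-linked thiophen-2-yl group common to all three compounds is also open, as no change at that place appears in this set.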